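Shortening the chain of compound 2

A few compounds are considered here, and "the series" means these few. Any claim that something is new, unique, unknown or untested is made for them only; others in the source may bear on it.

Compound 1 `COc1ccc2nc(NC(=O)CCCCC(=O)NO)sc2c1`: 23.9 ug/mL
Compound 2 `O=C(CCCCCCC(=O)Nc1nc2ccc([N+](=O)[O-])cc2s1)NO`: 1.65 ug/mL

In a functional assay on ASPC1 cells (Homo sapiens) for cytotoxicity (on this read-out higher numbers stand for weaker inhibition and lower numbers for stronger inhibition), compound 2 gives 1.65 ug/mL, the lower of the two numbers, and its gap to compound 1 lies beyond the scatter. Compound 3 `O=C(CCCCC(=O)Nc1nc2ccc([N+](=O)[O-])cc2s1)NO` has not yet been measured. It carries hydroxycarbamoyl in place of 2-(hydroxycarbamoyl)ethyl on a saturated chain carbon, four bonds along the chain from a carbonyl carbon. Within the data shown here, no measured pair shows this change alone. Compound 3 shares its chain with compound 1, which reads 23.9 ug/mL, but the two also differ in their cores, so only part of that gap is expected to carry over. A move towards weaker inhibition in this assay, probably beyond the scatter, is therefore expected, and the estimated change is a 3.0-fold higher number from compound 2 to compound 3 (0.48 log units; beyond the scatter). For compound 3 the estimate is 5 ug/mL, with an expected range of 1.5 ug/mL to 18 ug/mL.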

Compound 3, half-maximal inhibitory concentration: > 30 ug/mL
Compound 3 ended at the assay's limit; the forecaster's own chance of this, stated with the estimate: 3%; middle value at least 6.0-fold (0.77 log units) away from the limit.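

In this assay compound 3 gives > 30 ug/mL, which is a limit of the assay and not a number: the limit of > 30 ug/mL in this assay, at which 1 of the 3 values shown sits.

Among these compounds, with the core held, hydroxycarbamoyl in place of 2-(hydroxycarbamoyl)ethyl on a saturated chain carbon, four bonds along the chain from a carbonyl carbon, gives an at least 18-fold higher number from compound 2 to compound 3 (1.25 log units; beyond the scatter), the first reading of this chain change alone, and the step is large. With the chain held, nitro in place of methoxy on an aromatic carbon gives an at least 1.2-fold higher number from compound 1 to compound 3 (0.09 log units; that floor lies within the scatter), so this pair shows no core effect beyond the scatter.

On these data alone, how far compound 3 lies past the limit remains open, and with it the full size of both steps. Also open, as far as these compounds go, is whether a chain longer than that of compound 2 would lower the number further, and how an amine in place of nitro on the aromatic carbon would read.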